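The source may report more compounds than this note shows. Statements on the series, on what has been measured and on what is new or still open speak of the compounds shown alone.

In a functional assay on A549 cells (Homo sapiens) for antiproliferative activity, read by MTT assay, with a stated time of 48 h (a lower number here means a stronger inhibitor, a higher number a weaker inhibitor), compound 1 `COc1ccc(N(C)c2ccnc(Cl)n2)cc1OCCC[Se]C#N` gives 3710 nM. Compound 2 `COc1ccc(N(C)c2ccnc(Cl)n2)cc1OCCCC[Se]C#N` gives > 10000 nM, which is a limit of the assay and not a number, so its standing is known only as a limit. Compound 3 `COc1ccc(N(C)c2ccnc(Cl)n2)cc1OCCCCC[Se]C#N` differs from compound 2 by a group of 4 heavy atoms (2 carbon, 1 nitrogen, 1 selenium; no ring) in place of a group of 3 heavy atoms (1 carbon, 1 nitrogen, 1 selenium; no ring), on a saturated chain carbon, four bonds along the chain from an oxygen on an aromatic ring. Within the data shown here, one measured step bears on this: an at least 2.6-fold higher number from compound 1 to compound 2 (0.43 log units; beyond the scatter), the same kind of replacement, at three bonds along the chain rather than four. Among the measured compounds shown here, a further move to a higher number is therefore expected, though with only this one step behind it. The expected step is a step that the limit leaves unreadable from compound 2 to compound 3. Compound 3 is estimated at 12000 nM, with an expected range of 5000 nM to 30000 nM.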

Compound 3, half-maximal inhibitory concentration: > 10000 nM
Compound 3 gave a limit, no number (the forecaster's own chance of this, stated with the estimate: 65%); the middle value lies beyond the limit too.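

In this assay compound 3 gives > 10000 nM, a limit of the assay and not a number. The further lengthening of the chain leaves an at least 2.6-fold higher number from compound 1 to compound 3 (0.43 log units; beyond the scatter), so the higher number seen with compound 2 does not return to a measurable value with compound 3. The step between compound 2 and compound 3 cannot be read, because both sit at the same limit: the limit of > 10000 nM in this assay, at which 2 of the 3 values shown sit.

As far as these compounds go, how far either compound lies past the limit stays open. Also open, from the compounds shown here alone, is whether a shorter chain, or an amine or a carboxylic acid in place of the nitrile, would give a lower number in this assay.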